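Two ether-linked side chains on a shared aminoquinoline core

The source may hold more compounds than are shown below. What is called first, only, known or untested is meant among the compounds shown, and "the series" means these compounds.

Measured so far:
compound 1, `CCOCCOc1cccc2ccc(N)nc12`: > 2000 nM
compound 2, `CCC(CC)C(C)Oc1cccc2ccc(N)nc12`: 191 nM

The account concerns an assay on cells with melanin-concentrating hormone receptor 1 (Homo sapiens) as the target, read by radioligand binding; a lower number here means a stronger inhibitor, a higher number a weaker inhibitor. Compound 1 carries an ethoxyethoxy chain on the core. In this assay compound 1 gives only > 2000 nM, which is a limit of the assay and not a number. Going by these compounds, it therefore sits at the limit of > 2000 nM in this assay, at which 1 of the 2 values shown sits, so its true inhibitory concentration is unknown beyond that edge. Among the measured compounds shown here, compound 2, with a branched saturated alkoxy chain in the same position, gives 191 nM in this assay; since compound 1 has no number, no measured step between the two can be stated, only that compound 2 has a defined value where compound 1 has none.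

Compound 3, `CSCCOc1cccc2ccc(N)nc12`, has not yet been measured. It differs from compound 1 in one place: methylsulfanyl in place of ethoxy on a saturated chain carbon, two bonds along the chain from an oxygen on an aromatic ring. With compound 1 at a limit, the step from compound 1 to compound 3 can only be guessed. A modest gain is expected, an at least 1.3-fold lower number from compound 1 to compound 3 (0.12 log units; that floor lies within the scatter), though the outcome could again be a limit. In this assay compound 3 is expected to give about 1500 nM, likely between 400 nM and 5000 nM.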

Compound 3, half-maximal inhibitory concentration: > 2000 nM
Compound 3: no number, only a limit (the forecaster's own chance of this, stated with the estimate: 45%); at least 1.3-fold (0.12 log units) between middle value and limit.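

In this assay compound 3 gives > 2000 nM, which is a limit of the assay and not a number. Compound 1 stands at the same kind of limit, so no step between compound 1 and compound 3 can be read: the limit of > 2000 nM in this assay, at which 2 of the 3 values shown sit.

The compounds shown leave open whether methylsulfanyl in place of ethoxy changes the inhibitory concentration at all, and by how much.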